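Series notes: heptyl in place of 4-nitrophenyl

A few compounds are considered here, and "the series" means these few. Any claim that something is new, unique, unknown or untested is made for them only; others in the source may bear on it.

Measured so far in a functional assay on MCF7 cells (Homo sapiens) for inhibition, read by MTT assay, with a stated time of 48 h; on this read-out higher numbers stand for weaker inhibition and lower numbers for stronger inhibition:
compound 1 `O=[N+]([O-])c1ccc(C(c2c[nH]c3ccc([N+](=O)[O-])cc23)c2c[nH]c3ccc([N+](=O)[O-])cc23)cc1`: 22500 nM
compound 2 `CCCCCCCC(c1c[nH]c2ccc([N+](=O)[O-])cc12)c1c[nH]c2ccc([N+](=O)[O-])cc12`: 5800 nM
compound 3 `N#Cc1ccc2[nH]cc(C(c3ccc([N+](=O)[O-])cc3)c3c[nH]c4ccc(C#N)cc34)c2c1`: 23600 nM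

The change from compound 1 to compound 2 is heptyl in place of 4-nitrophenyl on a saturated chain carbon bound to two aromatic carbons; it gave a 3.9-fold lower number from compound 1 to compound 2 (0.59 log units; beyond the scatter). Compound 4 `CCCCCCCC(c1c[nH]c2ccc(C#N)cc12)c1c[nH]c2ccc(C#N)cc12` is not yet measured and arises from compound 3 by the same change, (heptyl in place of 4-nitrophenyl on a saturated chain carbon bound to two aromatic carbons). How the core of compound 3 differs from the core of compound 1 is not broken down here; the values of compound 3 and compound 1 lie within the scatter of each other, so neither can be placed above the other.

For compound 4 in this assay a step of about the earlier size is expected, a 3.6-fold lower number from compound 3 to compound 4 (0.56 log units; beyond the scatter). Among the measured compounds shown here, this rests on a single precedent, a 3.9-fold lower number from compound 1 to compound 2 (0.59 log units; beyond the scatter), with no second example to show whether the step carries over to the core of compound 3.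

Compound 4 is estimated at 6500 nM, with a likely range from 2500 nM to 17000 nM.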

Compound 4, half-maximal inhibitory concentration: 2500 nM
For compound 4 the middle estimate is 2.6-fold (0.41 log units) above the measured one, within the range that was stated.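

In this assay, heptyl in place of 4-nitrophenyl gave a 9.4-fold lower number from compound 3 to compound 4 (0.97 log units; beyond the scatter) on the second core. Two cores are a narrow base, so nothing follows for other cores or other assays, and the cause of the lower number stays unknown. Within these two cores the change carries over in direction, and its size cannot be told apart between them: the same change on two cores in this assay, a 3.9-fold lower number (0.59 log units; beyond the scatter) from compound 1 to compound 2 and a 9.4-fold lower number (0.97 log units; beyond the scatter) from compound 3 to compound 4, 2.4-fold (0.39 log units) apart, within the scatter of two such steps

The compounds shown leave open whether a shorter or longer chain than heptyl would keep this step. They also leave open whether a chain ending in an amine or a carboxylic acid would keep it.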